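The compounds below may be only part of what the source reports. "The series", "measured", "known", "first", "only" and "open" are said of these compounds alone.

Compound 3 `c1cc(-c2cncc(O[C@@H]3CCNC3)c2)ccn1` gives the highest number of the three measured in an assay on a protein complex for binding affinity to Neuronal acetylcholine receptor; alpha4/beta2 (Rattus norvegicus) (on this read-out lower numbers stand for stronger inhibition and higher numbers for weaker inhibition), at 571 nM. Compound 2 `Clc1ncc(O[C@@H]2CCNC2)cc1-c1ccccc1` gives 75 nM in this assay, and compound 1 `C#Cc1cc(O[C@@H]2CCNC2)cnc1Cl` gives 46 nM; both of these numbers sit beyond the scatter below the number of compound 3. Going by the values given here, the only single-point step among the measured compounds is a 1.6-fold higher number from compound 1 to compound 2 (0.21 log units; within the scatter), a change on the aryl group far from the ring nitrogen, which stayed within the scatter.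

Compound 4 `Clc1ncc(O[C@@H]2CCNC2)cc1-c1ccncc1` is reached from compound 3 by chloro in place of hydrogen on an aromatic carbon. Among the compounds with values here, no measured step covers this change on its own. Compound 2 carries the same chloro group together with a phenyl group, whereas compound 3 lacks the chloro group and carries a pyridin-4-yl group; the two values show a large gap, but it cannot be split between the two changes. Compound 4 holds the chloro group and the pyridin-4-yl group, so its number is expected to fall between those of compound 2 and compound 3, and the estimated step is a 3.4-fold lower number from compound 3 to compound 4 (0.53 log units; beyond the scatter) in this assay. For compound 4 the expected value in this assay is therefore 170 nM, with a range from 50 nM to 600 nM.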

Compound 4, half-maximal inhibitory concentration: 65 nM
Compound 4: the middle estimate sits 2.6-fold (0.42 log units) above what was measured, within the range that was stated.
By their numbers in this assay, from the lowest: compounds 1, 4 and 2 (each within the scatter of the next); then compound 3.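

Going by these compounds alone, with the pyridin-4-yl group held fixed, chloro in place of hydrogen on this aromatic carbon, next to the ring nitrogen and ortho to the pyridin-4-yl group, gives an 8.8-fold lower number from compound 3 to compound 4 (0.94 log units; beyond the scatter) in this assay and so provides the first single-place reading of this change, one that lies beyond the scatter. With the chloro group present, the choice of group on the other aromatic carbon makes no difference that this assay can resolve: both a 1.2-fold lower number from compound 2 to compound 4 (0.06 log units; within the scatter) and a 1.4-fold higher number from compound 1 to compound 4 (0.15 log units; within the scatter) stay within the scatter, so the pyridin-4-yl compound cannot be told apart from its phenyl or ethynyl counterpart. No evidence is available that accounts for the effect of the chloro group.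

Only compound 3 carries hydrogen on this carbon, so the compounds shown leave open whether chloro lowers the number to a similar extent when phenyl or ethynyl takes the place of the pyridin-4-yl group. They also leave open whether fluoro, bromo, methyl or an amine on the same carbon would match chloro in this assay.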